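The source may hold more compounds than are shown below. What is called first, only, known or untested is meant among the compounds shown, and "the series" means these compounds.

The compounds measured so far, all in a functional assay on HT-29 cells (Homo sapiens) for inhibition; a higher number here means a weaker inhibitor, a lower number a stronger inhibitor:

- compound 1, `CC(O)n1cnc2c(N)nc(I)nc21`. In this assay compound 1 gives > 500000 nM, which is a limit of the assay and not a number.
- compound 2, `CC(=O)OC(C)n1cnc2c(N)nc(I)nc21`. In this assay compound 2 gives > 500000 nM, again a limit rather than a number.
- compound 3, `CC(=O)OC(C)n1cnc2c(S)nc(F)nc21`. In this assay compound 3 gives > 500000 nM, also a limit.

Compound 2 and compound 1 differ in one place: hydrogen in place of acetyl on an oxygen on a saturated carbon. The step that the two limits leave unreadable from compound 2 to compound 1 cannot be read in size, since both values are limits. What is known is summed up in the evidence the limit of > 500000 nM in this assay, at which 3 of the 3 values shown sit: every value so far sits at the limit, so none of the three compounds has shown measurable inhibition in this assay.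

Compound 4, `CC(O)n1cnc2c(S)nc(F)nc21`, has not yet been measured. It is related to compound 3 by the same change that relates compound 2 to compound 1: hydrogen in place of acetyl on an oxygen on a saturated carbon. The place of the change is worded the same in both pairs, so this is the same change on a different core. The difference between the two cores, that of compound 2 and that of compound 3, is not broken down here.

For compound 4 in this assay the step that the limit leaves unreadable from compound 3 to compound 4 is the expectation, resting on the fact that compound 3 gives > 500000 nM and that the same change from compound 2 to compound 1 gave no readable movement. Compound 4 is therefore expected to give about 1000000 nM, most likely reported again as a limit, with a range from 300000 nM to 5000000 nM.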

Compound 4, half-maximal inhibitory concentration: > 500000 nM
Compound 4 ended at the assay's limit; the forecaster's own chance of this, stated with the estimate: 90%; the middle value does not contradict the limit.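

In this assay compound 4 gives > 500000 nM, which is a limit of the assay and not a number. Compound 3 also sits at a limit, so the change from acetoxy to hydroxy between compound 3 and compound 4 cannot be read in size. The compounds shown leave open how strongly any of them inhibits and whether this change matters at all: the limit of > 500000 nM in this assay, at which 4 of the 4 values shown sit.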